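Replacing (but-3-yn-1-yl)oxy on the carbonyl carbon

The source may hold more compounds than are shown below. What is called first, only, known or untested is meant among the compounds shown, and "the series" means these compounds.

In a functional assay on Caco-2 cells (Homo sapiens) for antiproliferative activity, read by MTT assay, with a stated time of 48 h (on this read-out higher numbers stand for weaker inhibition and lower numbers for stronger inhibition), compound 1 `CCn1c(C(=O)NCCCN(C)C)ccc1C(CC)(CC)c1ccc(OCCC(O)(CC)CC)c(C)c1` gives 490 nM. Compound 2 `CCN(CC)CCNC(=O)c1ccc(C(CC)(CC)c2ccc(OCCC(O)(CC)CC)c(C)c2)n1CC` gives 1630 nM. Compound 3 `C#CCCOC(=O)c1ccc(C(CC)(CC)c2ccc(OCCC(O)(CC)CC)c(C)c2)n1CC` gives > 50000 nM, which is a limit and not a number. It stands at the limit of > 50000 nM in this assay, at which 1 of the 3 values shown sits.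

The change to compound 4 `CCC(C)C(NC(=O)c1ccc(C(CC)(CC)c2ccc(OCCC(O)(CC)CC)c(C)c2)n1CC)C(=O)OC` is a group of 10 heavy atoms (7 carbon, 1 nitrogen, 2 oxygen; no ring) in place of a group of 5 heavy atoms (4 carbon, 1 oxygen; no ring), on a carbonyl carbon. For the measured compounds named here, two steps bear on it: an at least 100-fold higher number from compound 1 to compound 3 (2.00 log units; beyond the scatter), which is large, and a 3.3-fold higher number from compound 1 to compound 2 (0.52 log units; beyond the scatter), which is modest. Compound 4 carries an amide-type nitrogen but neither dimethylamino nor diethylamino, so only part of the large at least 30-fold higher number from compound 2 to compound 3 (1.48 log units; beyond the scatter) is expected to return in this assay, toward a lower number. The estimated step is an at least 6.2-fold lower number from compound 3 to compound 4 (0.79 log units; beyond the scatter). Compound 4 is expected at 8000 nM, with an estimated range of 1500 nM to 40000 nM.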

Compound 4, half-maximal inhibitory concentration: > 50000 nM
Compound 4 ended at the assay's limit (the forecaster's own chance of this, stated with the estimate: 25%); at least 6.2-fold (0.79 log units) between middle value and limit.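

In this assay, an amide-type nitrogen on the carbonyl carbon is not enough to bring the number down when the group it carries lacks dimethylamino and diethylamino: an at least 30-fold higher number from compound 2 to compound 4 (1.48 log units; beyond the scatter), and an at least 100-fold higher number from compound 1 to compound 4 (2.00 log units; beyond the scatter). Compound 4 gives > 50000 nM, which is a limit. The step from compound 3 to compound 4 cannot be read, since neither compound has a value short of the limit: the limit of > 50000 nM in this assay, at which 2 of the 4 values shown sit.

Still open, going by these compounds, is whether a carboxylic acid in place of the ester of compound 4 would give a readable value. Also open, on these data alone, is whether a dimethylamino group on that branched chain would do so.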